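The source may hold more compounds than are shown below. What is called first, only, known or untested is meant among the compounds shown, and "the series" means these compounds.

Compound 1 `C=C[C@@]1(C)O[C@H]1C[C@H]1C(=C)CC[C@@H]2[C@]1(C)CCC[C@]2(C)C(=O)O` was tested in a functional assay on MCF7 cells (Homo sapiens) for cytotoxicity, read by MTT assay, with a stated time of 48 h (a higher number here means a weaker inhibitor, a lower number a stronger inhibitor), and for compound 1 the result is a limit, > 40000 nM, so where compound 1 truly stands is not known from this number. Compound 2 `C=C[C@]1(C)O[C@H]1C[C@H]1C(=C)CC[C@@H]2[C@]1(C)CCC[C@]2(C)C(=O)O` likewise gives only a limit, > 40000 nM. Going by the values given here, compound 3 `C=CC(=C)CC[C@@H]1[C@@]2(C)CCC[C@](C)(COC(=O)/C=C\c3ccc(O)c(OC)c3)[C@@H]2CC[C@@]1(C)O` is the only compound of the three with a measured number, giving 15400 nM in this assay. Among the compounds with values here, the one step among the measured compounds, a step that the two limits leave unreadable from compound 1 to compound 2, cannot be read, because the limit of > 40000 nM in this assay, at which 2 of the 3 values shown sit, leaves both ends open even though the fact that compounds 1 and 2 differ only in the configuration as drawn makes it a change of configuration alone.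

Compound 4 `C=CC(=C)[C@H](O)C[C@H]1C(=C)CC[C@@H]2[C@]1(C)CCC[C@]2(C)C(=O)O` has not yet been measured. It differs from compound 1 in one place: a group of 6 heavy atoms (5 carbon, 1 oxygen; no ring) in place of a group of 6 heavy atoms (5 carbon, 1 oxygen; one three-membered non-aromatic ring with 1 hetero atom), on a saturated chain carbon bound to a saturated ring carbon. Within the data shown here, no measured step bears on a change of this kind, since the step from compound 1 to compound 2 touches only configuration and is unreadable in any case, and compound 3 is not connected to compound 1 by any single step. With nothing to pull the number away from where compound 1 stands, the estimate for compound 4 in this assay is 40000 nM, between 12000 nM and 120000 nM. The step this estimate implies, a number no higher from compound 1 to compound 4 (the limit leaves the size open), is expected to lie within the scatter.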

Compound 4, half-maximal inhibitory concentration: > 40000 nM
Compound 4: a limit, no number; the forecaster's own chance of this, stated with the estimate: 65%; the middle value sits exactly at the limit.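

Going by these compounds alone, neither the step to compound 4 from compound 1 nor the one from compound 2 can be read, and the cause is the same for both: the limit of > 40000 nM in this assay, at which 3 of the 4 values shown sit. The compounds shown leave open where compound 1, compound 2 and compound 4 truly stand in this assay, and whether opening the three-membered ring changes the result at all.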